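A few compounds are considered here, and "the series" means these few. Any claim that something is new, unique, unknown or untested is made for them only; others in the source may bear on it.

Measured so far in an in vitro ADME assay on microsomes from liver (Simiiformes); a lower number here means that the compound disappears faster, a higher number that the compound lasts longer:

Compound 1 `Cc1cc(CCCOc2c(C)cc(-c3noc(C)n3)cc2C)on1` gives 0.45 h.
Compound 2 `Cc1ccc(CCCOc2c(C)cc(-c3noc(C(F)(F)F)n3)cc2C)cn1` gives 1.97 h.
Compound 3 `COCc1cc(CCCOc2c(C)cc(-c3noc(C)n3)cc2C)on1` gives 0.5 h.

Compound 1 therefore sits at the short end of these three results, side by side with compound 3, whose number lies within the scatter of its own; compound 2 stands clearly apart from both, with a longer half-life in this assay that is beyond the scatter.

The step now in question leads from compound 1 to compound 4 `Cc1cc(CCCOc2c(C)cc(-c3noc(C(C)(F)F)n3)cc2C)on1`, which is not yet measured. 1,1-difluoroethyl in place of methyl on an aromatic carbon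

Among the measured compounds shown here, only one single-point step is available among the measured compounds, a 1.1-fold higher number from compound 1 to compound 3 (0.05 log units; within the scatter), and it concerns a different part of the molecule, the chain attached to the five-membered ring at the other end. It says nothing about the oxadiazole substituent. Compound 2 carries a trifluoromethyl on that same five-membered aromatic ring and shows the longer half-life in this assay, but it also differs from compound 1 in the ring at the far end of the chain, so the two values alone cannot be split into a contribution from each change.

On that thin basis, compound 4 is expected to run somewhat longer than compound 1, as a 2.0-fold higher number from compound 1 to compound 4 (0.30 log units; within the scatter), and its half-life in this assay is estimated at 0.9 h, within a range from 0.45 h to 1.9 h.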

Compound 4, half-life: 1.1 h
Compound 4: the middle estimate sits 1.2-fold (0.09 log units) below what was measured; the measured number falls inside the stated range.
By their numbers in this assay, from the lowest: compounds 1 and 3 (each within the scatter of the next); then compounds 4 and 2 (each within the scatter of the next).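

Among the compounds shown here, at this position the result gives the first reading of a single change that moves the half-life: in this assay, 1,1-difluoroethyl in place of methyl on the aromatic carbon next to the ring nitrogen and next to the ring oxygen gives a 2.4-fold higher number from compound 1 to compound 4 (0.39 log units; beyond the scatter). For the compounds shown here, the only earlier single change, methoxy on the saturated chain carbon, stayed within the scatter with a 1.1-fold higher number from compound 1 to compound 3 (0.05 log units; within the scatter), and compound 2 differs from compound 1 in more than one place, so neither showed that this substituent alone can shift the result. Nothing in the data shown accounts for the shift.

Going by these compounds, whether the step belongs to the two fluorine atoms or to the added carbon remains open, and ethyl at this position, compared directly with 1,1-difluoroethyl, would be needed to separate the two. Also open, on these data alone, is whether the same change would give a similar step in the setting of compound 3, with its methoxy group, or of compound 2, with its different ring at the far end of the chain.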